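The source may report more compounds than this note shows. Statements on the series, on what has been measured and on what is new or still open speak of the compounds shown alone.

Working notes on the series. The shared core of compound 1 `COc1ccc(Nc2cc(C)oc(=O)c2)cc1` carries a methyl group on an aromatic carbon; in a functional assay on A549 cells (Homo sapiens) for cytotoxicity, read by MTT assay, with a stated time of 72 h (on this read-out higher numbers stand for an effect only at larger amounts of compound and lower numbers for an effect already at smaller amounts), compound 1 gives only a limit, > 30 uM (the limit of > 30 uM in this assay, at which 1 of the 3 values shown sits). Compound 2 `COc1ccc(Nc2cc(C3CCCCC3)oc(=O)c2)cc1` replaces that methyl by cyclohexyl, and in this assay compound 2 gives 4.62 uM; this is an at least 6.4-fold lower number from compound 1 to compound 2 (0.81 log units; beyond the scatter). Compound 3 `COc1ccc(Nc2cc(-c3ccccc3)oc(=O)c2)cc1` carries phenyl instead, and in this assay compound 3 gives 0.093 uM; the step is an at least 320-fold lower number from compound 1 to compound 3 (2.50 log units; beyond the scatter), and from the cyclohexyl analogue it is a 50-fold lower number from compound 2 to compound 3 (1.70 log units; beyond the scatter). Compound 3 thus stands at the lowest number among the values shown, with compound 2 nearest.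

Compound 4 `COc1ccc(Nc2cc(C(C)C)oc(=O)c2)cc1` differs from compound 3 by isopropyl in place of phenyl on an aromatic carbon. Going by the values given here, the steps that bear on it are the two that remove phenyl: going to methyl gave an at least 320-fold lower number from compound 1 to compound 3 (2.50 log units; beyond the scatter) read in reverse, and going to cyclohexyl gave a 50-fold lower number from compound 2 to compound 3 (1.70 log units; beyond the scatter) read in reverse; both are large rises. Isopropyl is a saturated group of 3 heavy atoms, falling between the methyl of compound 1 and the cyclohexyl of compound 2, so a large upward step in this assay is expected for compound 4, an 86-fold higher number from compound 3 to compound 4 (1.93 log units; beyond the scatter). The estimate for compound 4 in this assay is 8 uM, within 2 uM to 30 uM.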

Compound 4, concentration for half-maximal effect: > 30 uM
Compound 4: a limit, no number (the forecaster's own chance of this, stated with the estimate: 20%); at least 3.7-fold (0.57 log units) between middle value and limit.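

In this assay, isopropyl at this place, next to the ring oxygen, does not keep what phenyl gives, with an at least 320-fold higher number from compound 3 to compound 4 (2.50 log units; beyond the scatter). It also falls short of cyclohexyl, with an at least 6.4-fold higher number from compound 2 to compound 4 (0.81 log units; beyond the scatter), so among the three groups without an aromatic ring only cyclohexyl gives a readable number, and compound 4 shows that the isopropyl group is not enough to reach one. The step from compound 1 to compound 4 cannot be read, since compound 1 and compound 4 both stand at a limit and not at a number: the limit of > 30 uM in this assay, at which 2 of the 4 values shown sit.

Open, from the compounds shown here alone, is whether the low number of compound 3 depends on an aromatic ring of carbon only or would survive in a pyridyl or thienyl ring, and whether a phenyl carrying a methoxy group or a fluorine would keep it. Also open, going by these compounds, is how a longer chain such as n-butyl or a smaller ring such as cyclopentyl would fall relative to cyclohexyl and isopropyl at this place.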